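The source may hold more compounds than are shown below. What is called first, only, known or untested is meant among the compounds shown, and "the series" means these compounds.

Compound 1 `O=C(c1ccc(Cl)cc1)N1CCC(NS(=O)(=O)c2cc(S(=O)(=O)c3ccccc3)ccc2C(F)(F)F)CC1`: 3100 nM
Compound 2 `O=C(c1ccccn1)N1CCC(NS(=O)(=O)c2cc(S(=O)(=O)c3ccccc3)ccc2C(F)(F)F)CC1`: 100000 nM
Compound 3 `O=S(=O)(NC1CCN(S(=O)(=O)c2ccccc2)CC1)c1cc(S(=O)(=O)c2ccccc2)ccc1C(F)(F)F`: 25000 nM

These values come from a physicochemical assay for solubility; a lower number here means a less soluble compound, a higher number a more soluble compound. The three compounds share one core and differ only in the group on an amine nitrogen in a ring. Compound 3 holds the middle place of the three, as two steps show: an 8.1-fold higher number from compound 1 to compound 3 (0.91 log units; beyond the scatter), and a 4.0-fold lower number from compound 2 to compound 3 (0.60 log units; beyond the scatter).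

Compound 4 `O=C(O)c1ccc(S(=O)(=O)N2CCC(NS(=O)(=O)c3cc(S(=O)(=O)c4ccccc4)ccc3C(F)(F)F)CC2)cc1` keeps all of compound 3 except for one change in its phenylsulfonyl group, which becomes (4-carboxyphenyl)sulfonyl. This puts carboxy in place of hydrogen on an aromatic carbon, para to a large group: carboxy in place of hydrogen on an aromatic carbon.

Going by the values given here, no measured compound carries a carboxy, so the evidence is indirect. All three measured steps changed the group on that ring nitrogen, and all went beyond the scatter, so this assay clearly responds to changes there. The closest parallel alters only an aromatic ring within that group, replacing 4-chlorophenyl with pyridin-2-yl on a carbonyl carbon: a 32-fold higher number from compound 1 to compound 2 (1.51 log units; beyond the scatter). On that single upward precedent, a modest rise is expected, smaller than that large step and with real doubt about its direction.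

The estimated step is a 2.8-fold higher number from compound 3 to compound 4 (0.45 log units; beyond the scatter).

Compound 4 is expected to give about 70000 nM, with an estimated range from 25000 nM to 160000 nM.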

Compound 4, solubility: 12500 nM
The estimate for compound 4 lay 5.6-fold (0.75 log units) above the measured number, outside the stated range (below it).
By their numbers in this assay, from the lowest: compound 1; then compounds 4 and 3 (each within the scatter of the next); then compound 2.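

In this assay, putting carboxy on an aromatic carbon of the phenylsulfonyl group, para to a large group, gives a 2.0-fold lower number from compound 3 to compound 4 (0.30 log units; within the scatter), so this single addition leaves no readable change. The wider swaps on the ring nitrogen still register, with an 8.0-fold lower number from compound 2 to compound 4 (0.90 log units; beyond the scatter) and a 4.0-fold higher number from compound 1 to compound 4 (0.61 log units; beyond the scatter). Every earlier step on that nitrogen went beyond the scatter, so compound 4 adds the first case in which a change within that group does not, which shows that not every alteration there moves the number.

No measurement available here bears on the reason for this result. Still open, as far as these compounds go, is whether an amine or a methyl ester on the same aromatic carbon would also stay within the scatter of compound 3, and whether carboxy would have a larger effect on the aromatic ring of the carbonyl-linked group of compound 1.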